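Nitrogen substituent variation on the indole series

A few compounds are considered here, and "the series" means these few. Any claim that something is new, unique, unknown or untested is made for them only; others in the source may bear on it.

In an assay on Prostate gland for inhibition of steroid 5-alpha-reductase (Rattus norvegicus) (on this read-out higher numbers stand for weaker inhibition and lower numbers for stronger inhibition), compound 1 `CCCCn1ccc2cc(/C(C)=C/C(=O)Nc3ccccc3OCCCC(=O)O)ccc21` gives 43 nM, and compound 2 `CCCCC(C)n1ccc2cc(/C(C)=C/C(=O)Nc3ccccc3OCCCC(=O)O)ccc21` gives 6 nM, the lowest of the two numbers; the change was a 7.2-fold lower number from compound 1 to compound 2 (0.86 log units; beyond the scatter). Compound 3 `C/C(=C\C(=O)Nc1ccccc1OCCCC(=O)O)c1ccc2c(ccn2Cc2cccc(C)c2)c1` carries 3-methylbenzyl in place of 1-methylpentyl on an aromatic nitrogen. For the measured compounds named here, the only measured step is the one from compound 1 to compound 2 at the same aromatic nitrogen, which shows that the group there moves the number, but no step to a benzylic group exists. Compound 3 is expected near compound 2, at a 1.7-fold higher number from compound 2 to compound 3 (0.22 log units; within the scatter), estimated at 10 nM within 2 nM to 50 nM.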

Compound 3, half-maximal inhibitory concentration: 250 nM
For compound 3 the middle estimate is 25-fold (1.40 log units) below the measured one; measured number above the stated range.
By their numbers in this assay, from the lowest: compound 2; then compound 1; then compound 3.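

In this assay the step of a 42-fold higher number from compound 2 to compound 3 (1.62 log units; beyond the scatter) shows that a ring-bearing group on the aromatic nitrogen does not keep the low number of the branched chain. The further step a 5.8-fold higher number from compound 1 to compound 3 (0.76 log units; beyond the scatter) places 3-methylbenzyl behind plain butyl as well, so both open chains give lower numbers here than this group. No measured evidence bears on the cause of this rise.

An unsubstituted benzyl would separate the contribution of the ring from that of its methyl. A cyclohexylmethyl group would test whether aromaticity of the ring matters.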